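The source may hold more compounds than are shown below. What is called first, only, known or untested is meant among the compounds shown, and "the series" means these compounds.

Measured compounds:
compound 1 `O=c1[nH]cnc2c1c(-c1cccs1)cn2[C@@H]1O[C@H](CO)[C@@H](O)[C@H]1O`: > 20000 nM
compound 2 `O=c1[nH]cnc2c1c(-c1ccco1)cn2[C@@H]1O[C@H](CO)[C@@H](O)[C@H]1O`: 2200 nM

In a functional assay on HL-60 cells (Homo sapiens) for antiproliferative activity, read by XTT assay, with a stated time of 72 h (on this read-out lower numbers stand for stronger inhibition and higher numbers for weaker inhibition), compound 2 gives the only number shown. For compound 1 the value is a limit of this assay, not a number (the limit of > 20000 nM in this assay, at which 1 of the 2 values shown sits). Among the measured compounds shown here, the single measured step, an at least 9.0-fold lower number from compound 1 to compound 2 (0.95 log units; beyond the scatter), concerns the five-membered ring alone. Compound 3 `O=c1[nH]cnc2c1c(-c1ccccc1)cn2[C@@H]1O[C@H](CO)[C@@H](O)[C@H]1O` brings (phenyl in place of furan-2-yl on an aromatic carbon). For the measured compounds named here, no measured step covers phenyl, so the expectation leans on compound 2 at 2200 nM and on the size of the one step, with a weaker outcome thought more likely. Compound 3 is expected at 10000 nM (range 2500 nM to 40000 nM). For compound 3 the expected step is a 4.5-fold higher number from compound 2 to compound 3 (0.66 log units; beyond the scatter), toward a higher number.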

Compound 3, half-maximal inhibitory concentration: > 20000 nM
Compound 3: no number, only a limit (the forecaster's own chance of this, stated with the estimate: 35%); middle value at least 2.0-fold (0.30 log units) away from the limit.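

In this assay, compound 3 gives a limit of the assay, not a number, so phenyl joins thiophen-2-yl at that limit: the limit of > 20000 nM in this assay, at which 2 of the 3 values shown sit.
Phenyl in place of furan-2-yl gives an at least 9.0-fold higher number from compound 2 to compound 3 (0.95 log units; beyond the scatter), which leaves furan-2-yl as the only one of the three groups on this aromatic carbon with a measured number. The step between compound 1 and compound 3 cannot be read, as both values are limits.

Open, from the compounds shown here alone, is whether furan-3-yl, a pyridine ring or a non-aromatic group such as methyl or a longer chain on this carbon would give a number in this assay.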